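The source may hold more compounds than are shown below. What is called first, only, known or untested is meant among the compounds shown, and "the series" means these compounds.

Of the compounds shown here, three have been tested in an ADME assay on MT4 cells (Homo sapiens) for cytotoxicity, read by MTT assay, with a stated time of 96 h; a higher number here means that more compound is tolerated, a lower number that less compound is tolerated. Compound 1 `CCC(=O)Nc1ccc(-c2nc3cc(C(F)(F)F)ccc3n2C2CCCCC2)cc1` gives 17000 nM, compound 3 `CC(=O)Nc1ccc(-c2nc3cc(C(F)(F)F)ccc3n2C2CCCCC2)cc1` gives 24000 nM, and compound 2 `CC(=O)Nc1ccc(-c2nc3ccccc3[nH]2)cc1` gives 100000 nM. The two cores, that of compound 2 and that shared by compound 1 and compound 3, differ in a way that is not broken down here.

Compound 1 differs from compound 3 by one change, (methyl in place of hydrogen on a saturated chain carbon bound to a carbonyl carbon). This change made a step of a 1.4-fold lower number from compound 3 to compound 1 (0.15 log units; within the scatter), which lies within the usual scatter of the assay.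

The unmeasured compound 4 `CCC(=O)Nc1ccc(-c2nc3ccccc3[nH]2)cc1` differs from compound 2 by the same change, (methyl in place of hydrogen on a saturated chain carbon bound to a carbonyl carbon), at the same place. Among the measured compounds shown here, since the only measured step of this kind, a 1.4-fold lower number from compound 3 to compound 1 (0.15 log units; within the scatter), was within the scatter, the expectation is that the move from compound 2 to compound 4 is small as well, and the estimated step is a 1.3-fold lower number from compound 2 to compound 4 (0.10 log units; within the scatter). On that basis compound 4 is expected to give about 80000 nM in this assay, with a likely range from 35000 nM to 150000 nM.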

Compound 4, half-maximal cytotoxic concentration: 35000 nM
Compound 4: the middle estimate sits 2.3-fold (0.36 log units) above what was measured; the range from low to high includes it.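

On the second core, the change from acetamido to propanoylamino made a step of a 2.9-fold lower number from compound 2 to compound 4 (0.46 log units; beyond the scatter) in this assay. Among the compounds shown here, the gap between this step and the earlier one on the shared core of compound 1 and compound 3 lies within the scatter, so these numbers give no sign that the core alters what the change does: the same change on two cores in this assay, a 1.4-fold lower number (0.15 log units; within the scatter) from compound 3 to compound 1 and a 2.9-fold lower number (0.46 log units; beyond the scatter) from compound 2 to compound 4, 2.0-fold (0.31 log units) apart, within the scatter of two such steps This does not prove that the change carries over unaltered, since only two pairs are available, one step lies within the scatter and the other beyond it, and the numbers give no explanation for either step.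

The compounds shown leave open how this assay responds when the propanoylamino group gives way at the same place to a longer chain, or to a chain ending in an amine or a carboxylic acid. They also leave open whether the same change behaves alike on a third core.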